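Benzylthio variation on the shared core: chloro to nitro

A few compounds are considered here, and "the series" means these few. Any claim that something is new, unique, unknown or untested is made for them only; others in the source may bear on it.

Measured compounds:
compound 1 `Cc1cc(N2CC[C@@H](C)[C@@H](N(C)c3ncnc4[nH]ccc34)C2)n2nc(SCc3ccc(Cl)cc3)nc2n1`: in a toxicity assay on GES1 cells (Homo sapiens) for inhibition, read by MTT assay, with a stated time of 72 h (a higher number here means a weaker inhibitor, a lower number a stronger inhibitor), compound 1 gives > 100000 nM, which is a limit of the assay and not a number.
compound 2 `Cc1cc(N2CC[C@@H](C)[C@@H](N(C)c3ncnc4[nH]ccc34)C2)n2nc(SCc3nc4ccccc4[nH]3)nc2n1`: in this assay compound 2 gives 40200 nM.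
compound 3 `Cc1cc(N2CC[C@@H](C)[C@@H](N(C)c3ncnc4[nH]ccc34)C2)n2nc(SCCc3ccccc3)nc2n1`: in this assay compound 3 gives 66200 nM.

Compound 1 stands only at the limit of > 100000 nM in this assay, at which 1 of the 3 values shown sits; no number is known for it. Compound 4 `Cc1cc(N2CC[C@@H](C)[C@@H](N(C)c3ncnc4[nH]ccc34)C2)n2nc(SCc3ccc([N+](=O)[O-])cc3)nc2n1` differs from compound 1 in one place: nitro in place of chloro on an aromatic carbon. Going by the values given here, no measured step exchanges chloro for nitro, so the steps that bear on this are the two that alter the same group on the saturated chain carbon bound to a sulfur in compound 1: an at least 2.4-fold lower number from compound 1 to compound 2 (0.39 log units; beyond the scatter) and an at least 1.5-fold lower number from compound 1 to compound 3 (0.17 log units; that floor lies within the scatter). Both run downward from the limit, one beyond the scatter and one not, and the pair differ from each other by a 1.6-fold higher number from compound 2 to compound 3 (0.22 log units; within the scatter). Any number read for compound 4 in this assay will by construction sit at or under the limit of compound 1, so the expected step is downward or none beyond the scatter. The step from compound 1 is expected as an at least 1.4-fold lower number from compound 1 to compound 4 (0.15 log units; that floor lies within the scatter). Compound 4 is thus expected near 70000 nM, between 30000 nM and 150000 nM, with a real chance that only a limit is reported again.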

Compound 4, half-maximal inhibitory concentration: 36600 nM
Estimate against measurement, compound 4: 1.9-fold (0.28 log units) above; measured number inside the range.
By their numbers in this assay, from the lowest: compounds 4, 2 and 3 (each within the scatter of the next). At a limit, above all of these: compound 1.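

In this assay, going by these compounds alone, the swap of chloro for nitro on an aromatic carbon, para to a large group, gives an at least 2.7-fold lower number from compound 1 to compound 4 (0.43 log units; beyond the scatter); the earlier steps replaced the whole aryl group on the chain carbon, whereas this one shows that a single substituent on the ring, with the rest of the (4-chlorobenzyl)sulfanyl arm kept, is enough to move the number beyond the scatter. Compound 1 stands only at a limit, which makes that step a floor and not a measured size: the limit of > 100000 nM in this assay, at which 1 of the 4 values shown sits. Against the other two measured arms, the steps are a 1.8-fold lower number from compound 3 to compound 4 (0.26 log units; within the scatter) and a 1.1-fold lower number from compound 2 to compound 4 (0.04 log units; within the scatter), so this assay does not separate the arms of compounds 2, 3 and 4 from one another.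

A 4-aminobenzyl, a 4-methoxybenzyl or an unsubstituted benzyl on the shared core would help show whether the shift follows the nitro group itself or the departure of chloro. From the compounds shown here alone, how far compound 4 truly lies from compound 1 remains open while compound 1 has no number.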